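A Trifluoromethoxy Group Enters the Anilino Ring of Compound 1

The source may report more compounds than this note shows. Statements on the series, on what has been measured and on what is new or still open speak of the compounds shown alone.

Measured compounds:
Compound 1, `Nc1ccccc1NC(=O)/C=C/c1ccc(Cn2cnc3c(Nc4ccccc4)nc(Cl)nc32)cc1`, 41.9%
Compound 2, `Nc1ccccc1NC(=O)c1ccc(Cn2cnc3c(Nc4ccccc4)nc(Cl)nc32)cc1`, 74.8%
Compound 3, `Nc1ccccc1NC(=O)c1ccc(Cn2cnc3c(Nc4ccc(-c5ccccn5)cc4)nc(Cl)nc32)cc1`, 41.2%

In a functional assay on HepG2 cells (Homo sapiens) for antiproliferative activity, read by CCK-8 assay, with a stated time of 72 h, tested at 8 uM (a lower number here means a weaker effect, a higher number a stronger effect of the compound at the concentration tested), compound 1 gives 41.9%. Of the three numbers this is the second highest; compound 3, which gives 41.2%, sits within the scatter of it, whereas compound 2, with 74.8%, lies clearly above it, as the step of a number 32.9 percentage points higher from compound 1 to compound 2 (beyond the scatter) shows.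

Compound 4, `Nc1ccccc1NC(=O)/C=C/c1ccc(Cn2cnc3c(Nc4cccc(OC(F)(F)F)c4)nc(Cl)nc32)cc1`, is the unmeasured compound. Its difference from compound 1 is trifluoromethoxy in place of hydrogen on an aromatic carbon. Among the measured compounds shown here, the new group enters the anilino ring, and the only measured step that touches that ring is a number 33.6 percentage points lower from compound 2 to compound 3 (beyond the scatter), where a pyridin-2-yl group in place of hydrogen brought a large fall. That step used a different group at a different place on the ring, so it gives only a rough hint that adding a group there can move the number by a large amount, most likely downward. For the measured compounds named here, no measured pair shows a trifluoromethoxy group at all, so the direction is uncertain.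

On this basis compound 4 is expected to give about 36% in this assay, within 18% to 58%, which means an estimated step of a number 5.9 percentage points lower from compound 1 to compound 4 (within the scatter).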

Compound 4, a percentage reported as inhibition, at one concentration (the size of the read-out at that concentration, not a potency): 37.6%
Beside the measured number, compound 4's estimate is 1.6 percentage points below it; measured number inside the range.
By their numbers in this assay, from the lowest: compounds 4, 3 and 1 (each within the scatter of the next); then compound 2.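

Adding a trifluoromethoxy group to the anilino ring of compound 1 gives a step in this assay of a number 4.3 percentage points lower from compound 1 to compound 4 (within the scatter), so this ring carbon of compound 1 accepts a group of five heavy atoms with no change that can be told from the usual scatter. Until now, the only substitution on the anilino ring was the pyridin-2-yl group, with a step of a number 33.6 percentage points lower from compound 2 to compound 3 (beyond the scatter), so the new result shows that adding a group to this ring does not always bring a large fall, though the two steps differ in group, in place and in parent compound. No measurement here explains why the number holds steady in compound 4.

The compounds shown leave open whether a trifluoromethoxy group at the same place would also leave the number unchanged in compound 2, which gives 74.8% and so has more room to fall. They also leave open what an amine or a carboxylic acid on this ring carbon would do, since a single group cannot show how far this tolerance extends.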